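The source may report more compounds than this note shows. Statements on the series, on what has been measured and on what is new or still open speak of the compounds shown alone.

Working notes on the series. Compound 1 `COC(=O)C1=C(C)NC(=O)N(C(=O)NCCCN2CCN(c3ccc(OC)cc3C)CC2)C1c1ccc(F)c(F)c1` is tested in an assay on liver for binding affinity to Alpha-1B adrenergic receptor (Homo sapiens), using microsomes (on this read-out higher numbers stand for weaker inhibition and lower numbers for stronger inhibition), and gives 510 nM; of the two numbers recorded, this is the highest. Compound 2 `COCC1=C(C(=O)OC)C(c2cc(F)c(F)cc2F)N(C(=O)NCCCN2CCN(c3ccccc3C(N)=O)CC2)C(=O)N1` in this assay gives 130 nM, a lower number than compound 1 and beyond the scatter. Compound 3 `COC(=O)C1=C(C)NC(=O)N(C(=O)NCCCN2CCN(c3ccc(Cl)cc3)CC2)C1c1ccc(F)c(F)c1` is not yet measured; it differs from compound 1 in one place: 4-chlorophenyl in place of 4-methoxy-2-methylphenyl on an amine nitrogen in a ring. Going by the values given here, no step between measured compounds covers this change, so only a guarded expectation is possible. For compound 3 the step of a 1.2-fold higher number from compound 1 to compound 3 (0.07 log units; within the scatter) is expected to stay within the scatter, with no clear direction. Compound 3 is estimated at 600 nM, within 200 nM to 1800 nM.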

Compound 3, inhibition constant: 17 nM
The estimate for compound 3 lay 35-fold (1.55 log units) above the measured number; measured number outside the range, below it.
By their numbers in this assay, from the lowest: compound 3; then compound 2; then compound 1.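

With the rest of compound 1 held constant, the group on the ring amine nitrogen proves a strong lever in this assay: 4-chlorophenyl in place of 4-methoxy-2-methylphenyl gives a 30-fold lower number from compound 1 to compound 3 (1.48 log units; beyond the scatter), a change that shifts the number far more than the earlier pair could show, as compound 1 and compound 2 differ in more than one place. Nothing at hand explains the size of this step.

From the compounds shown here alone, it remains open which part of the swap carries the step: the chlorine entering, or the methoxy or methyl leaving. Going by these compounds, whether an unsubstituted phenyl or a 4-fluorophenyl at this position would keep the number of compound 3 also remains open.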